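The source may report more compounds than this note shows. Statements on the series, on what has been measured and on what is new or still open speak of the compounds shown alone.

In a functional assay on the whole organism with Mus musculus as the target (a lower number here means that less compound is needed, a higher number that more compound is needed for the effect), three compounds have been measured so far. Compound 1 `Cc1ccc(-c2ccc(N3CCC(O)CC3)nn2)c(Cl)c1` gives 17 mg/kg, compound 2 `OC1CCN(c2ccc(-c3cc(Cl)ccc3Cl)nn2)CC1` gives 131 mg/kg, and compound 3 `CCCC(=O)OC1CCN(c2ccc(-c3ccccc3Cl)nn2)CC1` gives 39 mg/kg. Compound 3 therefore stands in the middle, with a higher number than compound 1 and a lower number than compound 2, and both gaps lie beyond the usual scatter of this kind of measurement.

Compound 4 `O=C(OC1CCN(c2ccc(-c3ccccc3Cl)nn2)CC1)C1CC1` differs from compound 3 in one place: cyclopropyl in place of propyl on a carbonyl carbon. Cyclopropyl stands in place of propyl on a carbonyl carbon, so the carbon count of the group stays the same while a ring appears. Among the compounds with values here, no pair of measured compounds shows a single change of this kind, so the data offer no direct guide to its size or direction.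

The expectation therefore starts from compound 3 at 39 mg/kg and assumes little movement. The estimated 1.1-fold lower number from compound 3 to compound 4 (0.05 log units; within the scatter) is small and is expected to stay within the scatter. For compound 4, the expected value is 35 mg/kg, with an estimated range of 16 mg/kg to 80 mg/kg.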

Compound 4, dose for half-maximal effect: 92 mg/kg
Compound 4: middle estimate off by 2.6-fold (0.42 log units), on the low side; measured number above the stated range.
By their numbers in this assay, from the lowest: compound 1; then compound 3; then compounds 4 and 2 (each within the scatter of the next).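

The position on the carbonyl carbon responds to more than the carbon count: in this assay, cyclopropyl in place of propyl gives a 2.4-fold higher number from compound 3 to compound 4 (0.37 log units; beyond the scatter), although both groups have the same number of carbons and neither has a hydrogen-bond donor or acceptor. The ring is the only difference counted between the two groups, and in this single pair it goes with more compound being needed for the effect. This pair shows the direction and size of the change, but no measurement here bears on what lies behind it.

From the compounds shown here alone, it remains open how a longer chain, a cyclobutyl ring or an amine on this carbonyl carbon would compare with propyl and cyclopropyl. It is also unknown whether the same swap would give a similar step on a different core.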